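The source may report more compounds than this note shows. Statements on the series, on what has been measured and on what is new or still open speak of the compounds shown alone.

Three compounds built on one shared core have been run in an ADME assay on MT4 cells (Homo sapiens) for cytotoxicity, read by MTT assay, with a stated time of 5 days; on this read-out lower numbers stand for higher toxicity in this test and higher numbers for lower toxicity in this test. Compound 1 `Cc1cc(C)c(Oc2cc(Nc3ccc(C#N)cc3)ncc2C(=O)NCc2cn(Cc3cccc([N+](=O)[O-])c3)nn2)c(C)c1` carries a 3-nitrophenyl on a saturated chain carbon bound to an aromatic nitrogen; in this assay compound 1 reaches only a limit of the measurement, >= 156000 nM. Compound 2 `Cc1cc(C)c(Oc2cc(Nc3ccc(C#N)cc3)ncc2C(=O)NCc2cn(CC(=O)N3CCOCC3)nn2)c(C)c1` bears a (morpholin-4-yl)carbonyl at that position, and in this assay compound 2 gives 181000 nM. Compound 3 `Cc1cc(C)c(Oc2cc(Nc3ccc(C#N)cc3)ncc2C(=O)NCc2cn(Cc3cccc(F)c3)nn2)c(C)c1` carries a 3-fluorophenyl there; in this assay compound 3 likewise ends at a limit, >= 204000 nM. The step of an at least 1.1-fold higher number from compound 2 to compound 3 (0.05 log units; that floor lies within the scatter) can be read only as a floor, and the steps a step that the limit leaves unreadable from compound 1 to compound 2 and a step that the two limits leave unreadable from compound 1 to compound 3 cannot be sized because the limit of >= 156000 nM in this assay, at which 1 of the 3 values shown sits, and the limit of >= 204000 nM in this assay, at which 1 of the 3 values shown sits, cap the numbers. Compound 3 thus stands at the ceiling of what the measurement reports, beside compound 1 and close to compound 2.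

Compound 4 `Cc1cc(C)c(Oc2cc(Nc3ccc(C#N)cc3)ncc2C(=O)NCc2cn(Cc3ccc(Cl)cc3)nn2)c(C)c1` differs from compound 3 by 4-chlorophenyl in place of 3-fluorophenyl on a saturated chain carbon bound to an aromatic nitrogen. Of the measured steps only an at least 1.1-fold higher number from compound 2 to compound 3 (0.05 log units; that floor lies within the scatter) touches this position, and it is a floor within the scatter; none compares two aryl groups. No change beyond the scatter is therefore expected, and the step of an at least 1.0-fold lower number from compound 3 to compound 4 (0.00 log units; that floor lies within the scatter) is estimated to be small. Compound 4 is expected to show 200000 nM, within 120000 nM to 320000 nM, most likely again reported as a limit.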

Compound 4, half-maximal cytotoxic concentration: >= 120000 nM
Compound 4: no number, only a limit; the forecaster's own chance of this, stated with the estimate: 75%; the middle value lies beyond the limit too.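

In this assay compound 4 reaches >= 120000 nM as a limit and not as a number. Among these compounds, no step from compound 1, compound 2 or compound 3 to compound 4 can be read. The compounds shown leave open whether 4-chlorophenyl and 3-fluorophenyl differ at all in this read-out.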